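Chloro to methoxy on compound 1

The source may report more compounds than this note shows. Statements on the series, on what has been measured and on what is new or still open speak of the compounds shown alone.

Going by the values given here, in a functional assay on PC-3 cells (Homo sapiens) (on this read-out lower numbers stand for stronger inhibition of growth and higher numbers for weaker inhibition of growth), compound 1 `Cc1cc(C)c2c(O)cc(-c3ccc(Cl)cc3)nc2n1` gives 6310 nM as the lowest of the three numbers measured so far. Compound 2 `COc1ccc(-c2cc(O)c3cccnc3n2)cc1` stands at 31600 nM and compound 3 `Oc1cc(-c2ccc(Cl)cc2)nc2ncccc12` at 47900 nM on the same read-out. Compound 4 `COc1ccc(-c2cc(O)c3c(C)cc(C)nc3n2)cc1` is still unmeasured. It differs from compound 1 in one place methoxy in place of chloro on an aromatic carbon and that change is methoxy in place of chloro on an aromatic carbon. Among the compounds with values here, the one measured step that bears on it is the same exchange run the other way, a 1.5-fold higher number from compound 2 to compound 3 (0.18 log units; within the scatter) with chloro in place of methoxy, and that step lies within the scatter. Read in reverse, it points to no step beyond the scatter in this assay for compound 4. Compounds 2 and 3 share a core that differs from the core of compound 1, so this single pair is only a modest guide. The expected step is a 1.3-fold lower number from compound 1 to compound 4 (0.10 log units; within the scatter) and would stay within the scatter. For compound 4 the estimated value is 5000 nM with an expected range from 2000 nM to 12500 nM as its likely span.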

Compound 4, concentration for 50% growth inhibition: 24000 nM
Estimate against measurement, compound 4: 4.8-fold (0.68 log units) below, outside the stated range (above it).
By their numbers in this assay, from the lowest: compound 1; then compounds 4, 2 and 3 (each within the scatter of the next).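

The earlier pair alone made this exchange look unimportant, but in this assay the core of compound 1 gives a 3.8-fold higher number from compound 1 to compound 4 (0.58 log units; beyond the scatter) and so loses growth inhibition when methoxy replaces chloro. At this position, on an aromatic carbon para to a large group, chloro and methoxy are therefore not interchangeable on every core. The size of the change depends on the core that carries it, as the two matched pairs show: the same change on two cores in this assay, a 1.5-fold higher number (0.18 log units; within the scatter) from compound 2 to compound 3 and a 3.8-fold lower number (0.58 log units; beyond the scatter) from compound 4 to compound 1, 5.8-fold (0.76 log units) apart, beyond the scatter of two such steps.

The compounds shown carry only chloro or methoxy at this position, so how an amine or a carboxylic acid there would behave stays open. They also leave unexplained why the two cores respond differently, and which of the two patterns a third core would follow.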